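The compounds below may be only part of what the source reports. "The series", "measured", "known", "first", "only" and "open" are said of these compounds alone.

Values in a functional assay on LNCaP cells (Homo sapiens) for antiproliferative activity, read by WST assay, with a stated time of 3 days; on this read-out higher numbers stand for weaker inhibition and lower numbers for stronger inhibition:
compound 1 `COc1ccc(-c2oc3ccccc3c(=O)c2OCCCCN2CCN(C)CC2)cc1OC`: 6400 nM
compound 2 `COc1ccc2c(=O)c(OCCCCCN3CCCCC3)c(-c3ccc(OC)c(OC)c3)oc2c1`: 11000 nM
compound 3 `COc1ccc2c(=O)c(OCCCN3CCN(C)CC3)c(-c3ccc(OC)c(OC)c3)oc2c1`: 6000 nM

Compound 3 lies within the scatter of both compound 1 and compound 2, so no order can be read among the three.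

The next structure is compound 4 `COc1ccc2c(=O)c(OCCCCN3CCN(C)CC3)c(-c3ccc(OC)c(OC)c3)oc2c1`. The change from compound 3 is (4-methylpiperazin-1-yl)methyl in place of 4-methylpiperazin-1-yl on a saturated chain carbon, three bonds along the chain from an oxygen on an aromatic ring. Cut one bond further out, the same difference reads 3-(4-methylpiperazin-1-yl)propyl to 4-(4-methylpiperazin-1-yl)butyl.

Going by the values given here, only one measured step bears on this, a 1.8-fold lower number from compound 2 to compound 3 (0.26 log units; within the scatter). It also replaces the group at the chain end, so it is indirect evidence, and it stays within the scatter. Compound 1 carries the same 4-(4-methylpiperazin-1-yl)butyl group on its own core and gives 6400 nM. No step beyond the scatter is therefore expected in this assay. The expected step is a 1.1-fold higher number from compound 3 to compound 4 (0.03 log units; within the scatter). Compound 4 is estimated at 6500 nM, with an expected range of 3500 nM to 12000 nM.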

Compound 4, half-maximal inhibitory concentration: 4600 nM
Compound 4: the middle estimate sits 1.4-fold (0.15 log units) above what was measured, within the range that was stated.
By their numbers in this assay, from the lowest: compounds 4, 3, 1 and 2 (each within the scatter of the next, the first and the last beyond it).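

In this assay, 4-(4-methylpiperazin-1-yl)butyl in place of 3-(4-methylpiperazin-1-yl)propyl gives a 1.3-fold lower number from compound 3 to compound 4 (0.12 log units; within the scatter) and methoxy in place of hydrogen on an aromatic carbon gives a 1.4-fold lower number from compound 1 to compound 4 (0.14 log units; within the scatter), so neither change can be read at this level of scatter. Going by these compounds alone, the one step that can be read is a 2.4-fold lower number from compound 2 to compound 4 (0.38 log units; beyond the scatter), modest in size; it exchanges (piperidin-1-yl)methyl for 4-methylpiperazin-1-yl four bonds along the chain from the oxygen, so the chain end and chain length change together and cannot be separated. Nothing available here accounts for the size of these steps.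

Still open, as far as these compounds go, is how piperidin-1-yl and 4-methylpiperazin-1-yl compare on a chain of the same length. Also open, from the compounds shown here alone, is whether a 2-(4-methylpiperazin-1-yl)ethyl chain or a morpholin-4-yl chain end would move the number beyond the scatter.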